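The source may hold more compounds than are shown below. What is called first, only, known or untested is meant among the compounds shown, and "the series" means these compounds.

Measured in a functional assay on ileum (Cavia porcellus) for antagonist activity; a higher number here means a weaker inhibitor, a lower number a stronger inhibitor:

- Compound 1 `CC(=O)c1ccc(OCCCOc2ccc3c(O)c([N+](=O)[O-])c(=O)oc3c2)cc1`: 6100 nM
- Compound 2 `N#Cc1ccc(OCCCOc2ccc3c(O)c([N+](=O)[O-])c(=O)oc3c2)cc1`: > 10000 nM, a limit of the assay
- Compound 3 `Cc1ccccc1OCCCOc1ccc2c(O)c([N+](=O)[O-])c(=O)oc2c1`: 590 nM

Compound 3 holds the lowest number shown, at 590 nM. Compound 4 `CC(=O)c1ccc(OCCCOc2ccc3c(O)c([N+](=O)[O-])c(=O)oc3c2)cc1O` is still unmeasured and has 4-acetyl-3-hydroxyphenyl in place of 2-methylphenyl on an oxygen on a saturated carbon. Among the measured compounds shown here, two measured steps bear on this change: a 10-fold lower number from compound 1 to compound 3 (1.01 log units; beyond the scatter) and an at least 16-fold lower number from compound 2 to compound 3 (1.22 log units; beyond the scatter), both large. For the measured compounds named here, compound 1 carries 4-acetylphenyl at that place, but no measured step covers the added hydroxy. A large step to a higher number in this assay is therefore expected. For compound 4 the estimate is 4000 nM, with an expected range of 1200 nM to 10000 nM. This would be an expected 6.8-fold higher number from compound 3 to compound 4 (0.83 log units; beyond the scatter).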

Compound 4, half-maximal inhibitory concentration: 2800 nM
For compound 4 the middle estimate is 1.4-fold (0.15 log units) above the measured one, within the range that was stated.
By their numbers in this assay, from the lowest: compound 3; then compound 4; then compound 1. At a limit, above all of these: compound 2.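

In this assay, adding a hydroxy to 4-acetylphenyl gives a 2.2-fold lower number from compound 1 to compound 4 (0.34 log units; beyond the scatter) and so shows that the number at this position can fall without giving up the acetyl group. Yet a 4.7-fold higher number from compound 3 to compound 4 (0.68 log units; beyond the scatter) shows that this gain leaves 4-acetyl-3-hydroxyphenyl short of 2-methylphenyl. The step of an at least 3.5-fold lower number from compound 2 to compound 4 (0.55 log units; beyond the scatter) is only a floor, and compound 2 stands at a limit: the limit of > 10000 nM in this assay, at which 1 of the 4 values shown sits.

From the compounds shown here alone, whether the same hydroxy would lower the number on 2-methylphenyl stays open. So does whether an amine or a methoxy in its place would do the same on 4-acetylphenyl.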